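Lipophilicity notes: sulfamoyl replaced by triazolyl on compound 2

This account rests on a few compounds, and the source may have more. Where it says the series, first, only, none or still open, it means among the compounds named here.

Measured so far:
compound 1 `COc1ccc(-c2cc(-c3cccc(S(C)(=O)=O)c3)cnc2N)cn1`, 2.3
compound 2 `COc1ccc(-c2cc(-c3ccc(S(N)(=O)=O)cc3)cnc2N)cn1`, 1.8
compound 3 `COc1ccc(-c2cnc(N)c(-c3ccc(OC)nc3)c2)cn1`, 2.8

In a physicochemical assay for lipophilicity, at pH 7.4 (on this read-out higher numbers stand for higher lipophilicity and lower numbers for lower lipophilicity), compound 2 gives 1.8, the lowest of the three numbers; compound 1 sits higher, beyond the scatter, and compound 3 higher still. Compound 4 `COc1ccc(-c2cc(-c3ccc(-n4cncn4)cc3)cnc2N)cn1` is not yet measured. It differs from compound 2 in one place: 1H-1,2,4-triazol-1-yl in place of sulfamoyl on an aromatic carbon. Among the measured compounds shown here, no step between two measured compounds covers this change, so its size cannot be read from the series; the expectation is a rise in this assay beyond the scatter, of moderate size. For compound 4 the estimate is 2.4, with a range from 1.9 to 2.9. The expected step from compound 2 to compound 4 is a number 0.60 log units higher from compound 2 to compound 4 (beyond the scatter).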

Compound 4, distribution coefficient: 2.4
Beside the measured number, compound 4's estimate shows no gap at the digits printed, within the range that was stated.
By their numbers in this assay, from the lowest: compound 2; then compounds 1 and 4 (each within the scatter of the next); then compound 3.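

Among the compounds shown here, at this position, on an aromatic carbon para to a large group, 1H-1,2,4-triazol-1-yl in place of sulfamoyl gives the only step the series can yet read in this assay, a number 0.60 log units higher from compound 2 to compound 4 (beyond the scatter), so the change does move this read-out. The entering group has 0 hydrogen-bond donors and the leaving group 1, but a single pair cannot separate that difference from the others. No measurement on hand ties the step to any feature of either group.

From the compounds shown here alone, whether an amine or a carboxylic acid on the same aromatic carbon would shift this assay in the same direction remains open. The compounds shown also leave open whether the step holds on a different core.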